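The compounds below may be only part of what the source reports. "The series", "measured", "known", "first", "only" and "open" are said of these compounds alone.

Measured so far in a physicochemical assay for permeability, using PAMPA, at pH 7.4; a higher number here means that the compound crosses the layer faster, a lower number that the compound crosses the layer more slowly:
- compound 1 `CC(C)C(=O)NCCS(=O)(=O)NC(=O)c1ccc(Nc2nc(NC3(c4ccc(Cl)cc4)CC3)nc(OCC(F)(F)F)n2)cc1` gives 13 nm/s
- compound 2 `O=C(NS(=O)(=O)CCNC(=O)C1CC1)c1ccc(Nc2nc(NC3(c4ccc(Cl)cc4)CC3)nc(OCC(F)(F)F)n2)cc1` gives 1 nm/s
- compound 3 `CC(C)(C)CNCCS(=O)(=O)NC(=O)c1ccc(Nc2nc(NC3(c4ccc(Cl)cc4)CC3)nc(OCC(F)(F)F)n2)cc1` gives 651 nm/s

Compound 3 stands highest of the three in this assay, and both gaps are well outside the usual scatter: a 50-fold higher number from compound 1 to compound 3 (1.70 log units; beyond the scatter) and a 650-fold higher number from compound 2 to compound 3 (2.81 log units; beyond the scatter). In each of those steps an acyl group on the amine nitrogen of the side chain was exchanged for neopentyl.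

Compound 4 `CC(=O)NCCS(=O)(=O)NC(=O)c1ccc(Nc2nc(NC3(c4ccc(Cl)cc4)CC3)nc(OCC(F)(F)F)n2)cc1` goes the opposite way from compound 3: acetyl in place of neopentyl on an amine nitrogen. The two measured steps that bear on this are the ones just named, both large, and compound 4 reverses their direction by putting an acyl group back on that nitrogen. Among the compounds with values here, no measured compound carries acetyl itself; compounds 1 and 2, which carry two other acyl groups, differ from each other by a 13-fold lower number from compound 1 to compound 2 (1.11 log units; beyond the scatter), so the size of the drop varies with the acyl group chosen. A large fall in this assay is therefore expected, a 130-fold lower number from compound 3 to compound 4 (2.11 log units; beyond the scatter), landing near the two amide-bearing compounds rather than near compound 3. Compound 4 is estimated at 5 nm/s, with a range of 1 nm/s to 30 nm/s.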

Compound 4, apparent permeability: 7 nm/s
Beside the measured number, compound 4's estimate is 1.4-fold (0.15 log units) below it, and the stated range covers the measured number.
By their numbers in this assay, from the lowest: compound 2; then compounds 4 and 1 (each within the scatter of the next); then compound 3.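

Acetyl on the amine nitrogen brings a 93-fold lower number from compound 3 to compound 4 (1.97 log units; beyond the scatter) in this assay, so a third acyl group also stands far from neopentyl, and in all three acyl compounds shown the number lies well below that of compound 3. Among these acyl groups, what sits on the carbonyl carbon matters only in part: methyl and isopropyl cannot be told apart, with a 1.9-fold lower number from compound 1 to compound 4 (0.27 log units; within the scatter), whereas a 7.0-fold higher number from compound 2 to compound 4 (0.85 log units; beyond the scatter) sets the cyclopropyl of compound 2 apart, so its especially low number belongs to that group and not to acyl groups in general. Nothing available explains any of these differences.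

The compounds shown leave open whether the high number of compound 3 goes with any simple alkyl group on that nitrogen or with neopentyl in particular, a question that an ethyl group or the free primary amine could help settle. They also leave open whether the low number is peculiar to cyclopropyl, which a cyclobutyl or tert-butyl group on the carbonyl carbon could test.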